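Swapping the Side Group on a Fluoromethyl Ketone Peptide

A few compounds are considered here, and "the series" means these few. Any claim that something is new, unique, unknown or untested is made for them only; others in the source may bear on it.

Measured compounds:
- compound 1, `CC[C@H](C)[C@H](NC(=O)OCc1ccccc1)C(=O)N1CCC[C@H]1C(=O)N[C@@H](CCCNC(=N)N)C(=O)CF`, gives 2440 nM
- compound 2, `N=C(N)NCCC[C@H](NC(=O)[C@@H]1CCCN1C(=O)[C@@H](NC(=O)OCc1ccccc1)C1CCCCC1)C(=O)CF`, gives 1450 nM
- compound 3, `CC(C)(C)[C@H](NC(=O)OCc1ccccc1)C(=O)N1CCC[C@H]1C(=O)N[C@@H](CCCNC(=N)N)C(=O)CF`, gives 1440 nM

All three were tested in a functional assay on OCI-Ly3 cells (Homo sapiens) for inhibition, read by CellTiter-Glo, with stated times of 48 h and 96 h; on this read-out lower numbers stand for stronger inhibition of growth and higher numbers for weaker inhibition of growth. They share one core and differ only in the group on a saturated chain carbon bound to an amide-type nitrogen and a carbonyl carbon. Compound 3 has the lowest number of the three, but the two steps that lead to it are a 1.0-fold lower number from compound 2 to compound 3 (0.00 log units; within the scatter) and a 1.7-fold lower number from compound 1 to compound 3 (0.23 log units; within the scatter), so nothing separates these three beyond ordinary repeat variation.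

Compound 4, `N=C(N)NCCC[C@H](NC(=O)[C@@H]1CCCN1C(=O)[C@@H](NC(=O)OCc1ccccc1)c1ccccc1)C(=O)CF`, is the next in the series. It differs from compound 3 as follows: phenyl in place of tert-butyl on a saturated chain carbon bound to an amide-type nitrogen and a carbonyl carbon. Among the compounds with values here, the steps that bear on this are the earlier swaps at the same place: a 1.7-fold lower number from compound 1 to compound 2 (0.23 log units; within the scatter), a 1.7-fold lower number from compound 1 to compound 3 (0.23 log units; within the scatter) and a 1.0-fold lower number from compound 2 to compound 3 (0.00 log units; within the scatter). Each of these changed the group at that position and none moved the number beyond the scatter. On that basis the change to compound 4 is expected to be a 1.1-fold higher number from compound 3 to compound 4 (0.05 log units; within the scatter), no clear direction. Compound 4 is therefore estimated at 1600 nM, with a range of 600 nM to 4500 nM.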

Compound 4, concentration for 50% growth inhibition: 8050 nM
Compound 4: the middle estimate sits 5.0-fold (0.70 log units) below what was measured; the measured number lies above the stated range.
By their numbers in this assay, from the lowest: compounds 3, 2 and 1 (each within the scatter of the next); then compound 4.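

In this assay this position turns out not to accept every group alike: phenyl in place of tert-butyl gives a 5.6-fold higher number from compound 3 to compound 4 (0.75 log units; beyond the scatter) and phenyl in place of cyclohexyl gives a 5.6-fold higher number from compound 2 to compound 4 (0.74 log units; beyond the scatter) while phenyl in place of sec-butyl gives a 3.3-fold higher number from compound 1 to compound 4 (0.52 log units; beyond the scatter) and all three steps lie beyond the scatter. Sec-butyl, tert-butyl and cyclohexyl stay within the scatter of one another, so among the four compounds only phenyl, with its six-membered aromatic ring of carbon only, moves the number clearly, and it moves it toward weaker inhibition of growth. No measurement at hand accounts for this difference between phenyl and the other three groups.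

What the compounds shown leave open is whether this loss belongs to phenyl alone or to aromatic rings at this position more widely, and a pyridine ring or a benzyl group there would bear on that question. Also open, on these data alone, is how an amine or a carboxylic acid on this carbon would read, and whether any group can take the number beyond the scatter in the other direction.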